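This account rests on a few compounds, and the source may have more. Where it says the series, first, only, none or still open, it means among the compounds named here.

Of the compounds shown here, two have so far been tested in a functional assay on HL-60 cells (Homo sapiens) for cytotoxicity, read by MTT assay, with a stated time of 72 h; a higher number here means a weaker inhibitor, a lower number a stronger inhibitor. Compound 1 `Clc1ccccc1-c1nnc2nnc(N3CCCC3)nn12` gives 2660 nM in this assay, the lowest of the two numbers. Compound 2 `Fc1ccc(-c2nnc3nnc(N4CCCC4)n3n2)cc1` gives 4560 nM in this assay, and since that number lies within the usual scatter of the number for compound 1, the two compounds cannot be told apart on this evidence. Compound 3 `CCc1nnc2nnc(N3CCCC3)nn12` has not yet been measured in this assay. It differs from compound 1 in a single place: ethyl in place of 2-chlorophenyl on an aromatic carbon. Within the data shown here, no measured pair shows what such a change does here, so the expectation rests only on compound 1 and on the fact that a ring-bearing group gives way to a short chain. The expected step is a 2.6-fold higher number from compound 1 to compound 3 (0.42 log units; beyond the scatter), toward a weaker inhibitor, though the uncertainty is wide. Compound 3 is therefore expected to give about 7000 nM in this assay, within a range from 2500 nM to 25000 nM.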

Compound 3, half-maximal inhibitory concentration: 47000 nM
Compound 3: the middle estimate sits 6.7-fold (0.83 log units) below what was measured, outside the stated range (above it).
By their numbers in this assay, from the lowest: compounds 1 and 2 (each within the scatter of the next); then compound 3.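

In this assay, ethyl in place of 2-chlorophenyl on this aromatic carbon gives an 18-fold higher number from compound 1 to compound 3 (1.25 log units; beyond the scatter), toward a weaker inhibitor, so the group at this position clearly matters to the read-out. The change removes a six-membered aromatic ring and a chlorine together, leaving 2 heavy atoms where there were 7, while the counts of hydrogen-bond donors and acceptors and the net charge stay the same. Nothing measured here explains the step. The ring and the chlorine therefore cannot yet be separated, and plain phenyl at this position would show what the chlorine alone contributes. A longer chain such as butyl would show whether a chain can recover the number of compound 1 without any ring.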